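The compounds below may be only part of what the source reports. "The series", "measured", "known", "first", "only" and "open" are said of these compounds alone.

Compound 3, whose structure is `COC(=O)C1(c2ccc([N+](=O)[O-])cc2)CC1CN1CCN(c2ncccn2)CC1`, stands second highest of the three numbers measured in an assay for displacement of a labelled ligand from Sigma non-opioid intracellular receptor 1 (Cavia porcellus); a higher number here means a weaker inhibitor, a lower number a stronger inhibitor. Compound 3 gives 619 nM. Its nearest neighbour is compound 1, `COC(=O)C1(c2ccc(C)cc2)CC1CN1CCN(c2ccccn2)CC1`, which carries a methyl in place of the nitro and a different heteroaryl on the piperazine; in this assay compound 1 gives 497 nM. Furthest away is compound 2, `COC(=O)C1(c2ccccc2)CC1CN1CCN(c2ncccn2)CC1`, the unsubstituted parent; compound 2 gives 3090 nM. For the measured compounds named here, the one step measured within this set is a 5.0-fold lower number from compound 2 to compound 3 (0.70 log units; beyond the scatter).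

Compound 4, `COC(=O)C1(c2ccc(C)cc2)CC1CN1CCN(c2ncccn2)CC1`, differs from compound 3 by methyl in place of nitro on an aromatic carbon. Going by the values given here, no measured step reports the exchange of nitro for methyl directly. The step bearing on it is a 5.0-fold lower number from compound 2 to compound 3 (0.70 log units; beyond the scatter), which shows that the nitro is worth a modest improvement over hydrogen. Whether methyl recovers part of that gain is not shown by any pair here; compound 1 with a methyl at that position gives 497 nM, but it also differs in the heteroaryl, so its value speaks only loosely.

Compound 4 is therefore expected to show a small shift, a 1.6-fold higher number from compound 3 to compound 4 (0.21 log units; within the scatter), likely toward a higher number but possibly within the scatter. The estimate for compound 4 in this assay is 1000 nM, with a range from 350 nM to 3000 nM.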

Compound 4, inhibition constant: 353 nM
Estimate against measurement, compound 4: 2.8-fold (0.45 log units) above; low and high end bracket the measured number.
By their numbers in this assay, from the lowest: compounds 4, 1 and 3 (each within the scatter of the next); then compound 2.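

Against the unsubstituted compound 2, methyl on this aromatic carbon, para to a large group, gives an 8.8-fold lower number from compound 2 to compound 4 (0.94 log units; beyond the scatter) in this assay, so the gain at this position seen with nitro (a 5.0-fold lower number from compound 2 to compound 3 (0.70 log units; beyond the scatter)) is not confined to that group. The exchange of nitro for methyl gives a 1.8-fold lower number from compound 3 to compound 4 (0.24 log units; within the scatter), so the two substituents cannot be told apart here, even though nitro brings more heavy atoms and two hydrogen-bond acceptors while methyl brings neither. The heteroaryl on the piperazine can now be read on its own, and pyrimidin-2-yl in place of pyridin-2-yl gives a 1.4-fold lower number from compound 1 to compound 4 (0.15 log units; within the scatter), which leaves compound 1 and compound 4 indistinguishable in this assay. No supporting evidence accompanies these numbers to account for them.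

From the compounds shown here alone, whether a chlorine or a methoxy group on the same aromatic carbon would match methyl and nitro remains open. So does whether this position tolerates a larger group such as phenyl, and whether its gain would survive replacing the methyl ester with a carboxylic acid or an amide.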